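The source may hold more compounds than are shown below. What is called first, only, known or untested is meant among the compounds shown, and "the series" means these compounds.

In an ADME assay on MDBK cells (Bos taurus) for cytotoxicity, read by MTT assay, with a stated time of 96 h (on this read-out lower numbers stand for higher toxicity in this test and higher numbers for lower toxicity in this test), compound 1 (`CCCC[C@H]1CC[C@H](c2ccc(NC(=S)Nc3cccc(C(F)(F)F)c3)cc2)CC1`) gives 10000 nM and compound 2 (`FC(F)(F)c1cccc(NC(=S)Nc2ccccc2)c1`) gives 49000 nM. For the measured compounds named here, compound 2 therefore holds the higher of only two numbers, which here means the lower toxicity in this test.

Compound 3 (`C=C(C)CNC(=S)Nc1cccc(C(F)(F)F)c1`) keeps most of compound 2 but has 2-methylprop-2-en-1-yl in place of phenyl on an amide-type nitrogen. Going by the values given here, no measured pair makes this exact change, so the evidence is indirect. Among the compounds with values here, the one step available is a 4.9-fold higher number from compound 1 to compound 2 (0.69 log units; beyond the scatter), in which hydrogen takes the place of 4-butylcyclohexyl on an aromatic carbon. That step is modest, and it removes a different group at a different place. It shows only that, in this single pair, the compound with fewer atoms gave the higher number.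

Within the data shown here, on the strength of the step to compound 2 of a 4.9-fold higher number from compound 1 to compound 2 (0.69 log units; beyond the scatter), a small rise in this assay is expected, probably no larger than that step. The estimated change is a 1.4-fold higher number from compound 2 to compound 3 (0.15 log units; within the scatter). For compound 3 the expected value is 70000 nM, with an estimated range from 25000 nM to 160000 nM.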

Compound 3, half-maximal cytotoxic concentration: > 100000 nM
Compound 3: only a limit was reported; the forecaster's own chance of this, stated with the estimate: 45%; at least 1.4-fold (0.15 log units) between middle value and limit.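

For the compounds shown here, until now the only step lay on an aromatic carbon, whereas this one lies on an amide-type nitrogen, where 2-methylprop-2-en-1-yl takes the place of phenyl and gives an at least 2.0-fold higher number from compound 2 to compound 3 (0.30 log units; that floor lies within the scatter). The floor of that step lies within the scatter, so the step does not firmly establish a difference in this assay, but it does show that this change, which removes the only ring at this nitrogen and brings in a double bond, produced no drop in the number and so no sign of higher toxicity in this test. Compound 3 gives > 100000 nM, which is a limit of the assay and not a number, so the true size of the step cannot be read: the limit of > 100000 nM in this assay, at which 1 of the 3 values shown sits.

The compounds shown cannot separate the loss of the ring from the arrival of the double bond, and a 2-methylpropyl chain, which has no double bond, or a benzyl group, which keeps a ring, on the same nitrogen would be needed to tell these two apart. As far as these compounds go, it also remains open whether the same change would behave alike in a compound that carries 4-butylcyclohexyl, as compound 1 does.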